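Ester swap at the carbonyl carbon of compound 3

A few compounds are considered here, and "the series" means these few. Any claim that something is new, unique, unknown or untested is made for them only; others in the source may bear on it.

Compound 3 `O=C(OCCc1c(-c2ccccc2Cl)c2cc(Cl)ccc2[nH]c1=O)c1ccc([N+](=O)[O-])cc1` stands highest of the three measured compounds in an ADME assay on HepG2 2.2.15 cells (Homo sapiens) for cytotoxicity (a higher number here means that more compound is tolerated, a lower number that less compound is tolerated), giving 1600000 nM. Compound 1 `CCCC(=O)OCCc1c(-c2ccccc2Cl)c2cc(Cl)ccc2[nH]c1=O` gives 52000 nM and compound 2 `CC(=O)NCC(=O)OCCc1c(-c2ccccc2Cl)c2cc(Cl)ccc2[nH]c1=O` gives 110000 nM. The steps of a 2.1-fold higher number from compound 1 to compound 2 (0.33 log units; beyond the scatter), a 15-fold higher number from compound 2 to compound 3 (1.16 log units; beyond the scatter) and a 31-fold higher number from compound 1 to compound 3 (1.49 log units; beyond the scatter) show that the group on the carbonyl carbon shifts this number strongly. Compound 4 `COc1ccc(/C=C/C(=O)OCCc2c(-c3ccccc3Cl)c3cc(Cl)ccc3[nH]c2=O)cc1OC` is changed at the same place: 2-(3,4-dimethoxyphenyl)ethenyl in place of 4-nitrophenyl on a carbonyl carbon. The measured steps bear on it only loosely; none of them exchanges one aromatic group for another, and the two largest move toward 4-nitrophenyl. A modest downward step a 3.2-fold lower number from compound 3 to compound 4 (0.51 log units; beyond the scatter) is therefore expected. Compound 4 is estimated at 500000 nM, within 100000 nM to 2000000 nM.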

Compound 4, half-maximal cytotoxic concentration: > 1200000 nM
Compound 4 gave a limit, no number (the forecaster's own chance of this, stated with the estimate: 25%); at least 2.4-fold (0.38 log units) between middle value and limit.
By their numbers in this assay, from the lowest: compound 1; then compound 2; then compound 3.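

In this assay compound 4 returned a limit and not a number: the limit of > 1200000 nM in this assay, at which 1 of the 4 values shown sits. The step from compound 3 to compound 4 cannot be read. Even so, 2-(3,4-dimethoxyphenyl)ethenyl on the carbonyl carbon gives an at least 10-fold higher number from compound 2 to compound 4 (1.03 log units; beyond the scatter) and an at least 23-fold higher number from compound 1 to compound 4 (1.36 log units; beyond the scatter), so a second group carrying an aromatic ring joins 4-nitrophenyl well clear of propyl and acetamidomethyl.

The compounds shown leave open whether the aromatic ring itself accounts for this. Also open, on these data alone, is where a plain phenyl group, an amine or a carboxylic acid at this carbonyl carbon would fall.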